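Compound 3 to compound 4: moving the fluorine

The source may hold more compounds than are shown below. What is called first, only, known or untested is meant among the compounds shown, and "the series" means these compounds.

In a functional assay on SK-BR-3 cells (Homo sapiens) for inhibition, read by MTT assay (a lower number here means a stronger inhibitor of growth, a higher number a weaker inhibitor of growth), compound 1 (`CC1=C(/C=C/C(C)=C/C=C/C(C)=C\C(=O)Nc2ccc(O)cc2)C(C)(C)CCC1n1ccnc1`) gives 3890 nM, compound 2 (`CC1=C(/C=C/C(C)=C/C=C/C(C)=C\C(=O)NCc2cccc(F)c2)C(C)(C)CCC1n1ccnc1`) gives 4240 nM and compound 3 (`CC1=C(/C=C/C(C)=C/C=C/C(C)=C\C(=O)Nc2cccc(F)c2)C(C)(C)CCC1n1ccnc1`) gives 17000 nM, the highest number of the three. Compound 4 (`CC1=C(/C=C/C(C)=C/C=C/C(C)=C\C(=O)Nc2ccc(F)cc2)C(C)(C)CCC1n1ccnc1`) carries 4-fluorophenyl in place of 3-fluorophenyl on an amide-type nitrogen. Within the data shown here, no measured step isolates this change. The nearest evidence is a 4.4-fold higher number from compound 1 to compound 3 (0.64 log units; beyond the scatter), where 4-hydroxyphenyl is replaced by 3-fluorophenyl, and a 4.0-fold higher number from compound 2 to compound 3 (0.60 log units; beyond the scatter) is of similar size. Both are modest, so only part of the first is expected to return with 4-fluorophenyl. The expected step is a 1.9-fold lower number from compound 3 to compound 4 (0.28 log units; within the scatter). The estimate for compound 4 is 9000 nM, with an expected range from 3500 nM to 20000 nM.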

Compound 4, concentration for 50% growth inhibition: 25100 nM
For compound 4 the middle estimate is 2.8-fold (0.45 log units) below the measured one; measured number above the stated range.
By their numbers in this assay, from the lowest: compounds 1 and 2 (each within the scatter of the next); then compounds 3 and 4 (each within the scatter of the next).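

In this assay, 4-fluorophenyl in place of 3-fluorophenyl on the amide-type nitrogen gives a 1.5-fold higher number from compound 3 to compound 4 (0.17 log units; within the scatter), so moving the fluorine makes no difference that can be told from the scatter. Fluoro in place of hydroxy on an aromatic carbon, the one-place change, gives a 6.5-fold higher number from compound 1 to compound 4 (0.81 log units; beyond the scatter), and 4-fluorophenyl in place of 3-fluorobenzyl gives a 5.9-fold higher number from compound 2 to compound 4 (0.77 log units; beyond the scatter). Nothing available explains these steps.

Still open, from the compounds shown here alone, is whether an amine or a carboxylic acid on that aromatic carbon would match hydroxy, and whether 4-fluorobenzyl would match 3-fluorobenzyl.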